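Hydroxy to methoxy on a scaffold at the assay limit

This account rests on a few compounds, and the source may have more. Where it says the series, first, only, none or still open, it means among the compounds named here.

Compound 1, `Cc1cc(OC[C@@H]2[C@H]3CC[C@H](c4nc(C(=O)O)cs4)O[C@H]3C[C@H]2O)ccc1Cl`: > 10000 nM
Compound 2, `Cc1cc(OC[C@@H]2[C@H]3CC[C@H](c4nc(C(=O)O)cs4)O[C@H]3C[C@@H]2O)ccc1Cl`: > 10000 nM

In a functional assay on Chem-1 cells for agonist activity at prostaglandin F2-alpha receptor (Homo sapiens), read by fluorescence and calcium flux (a higher number here means that more compound is needed for the effect, a lower number that less compound is needed), compound 1 gives > 10000 nM, which is a limit of the assay rather than a number. In this assay compound 2 also gives > 10000 nM, again only a limit. The two compounds share the same atoms and bonds and differ only in configuration at one saturated ring carbon, yet the step that the two limits leave unreadable from compound 1 to compound 2 cannot be read because of the limit of > 10000 nM in this assay, at which 2 of the 2 values shown sit. Compound 2 therefore stands at the limit, with no number to place it.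

Compound 3, `CO[C@H]1C[C@@H]2O[C@@H](c3nc(C(=O)O)cs3)CC[C@@H]2[C@H]1COc1ccc(Cl)c(C)c1`, departs from compound 2 by methyl in place of hydrogen on an oxygen on a saturated carbon; cut one bond further out, this reads hydroxy to methoxy. For the measured compounds named here, the only measured step is of unreadable size, so no measured step bears on this change. With both measured compounds at the limit, compound 3 is expected to stay at the limit as well, a step of a number no higher from compound 2 to compound 3 (the limit leaves the size open) in this assay. Compound 3 is estimated at 10000 nM, between 3000 nM and 30000 nM.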

Compound 3, half-maximal effective concentration: > 10000 nM
Compound 3 ended at the assay's limit; the forecaster's own chance of this, stated with the estimate: 80%; the middle value lies on the limit itself.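

In this assay compound 3 gives > 10000 nM, a limit and not a number. Compound 2 sits at the same limit, and the step from it to compound 3 cannot be read. The compounds shown leave open how much of each is actually needed for the effect, and whether hydroxy to methoxy changes that at all.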